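Naphthylmethyl piperidine amides: swapping the benzoyl ring

The source may hold more compounds than are shown below. What is called first, only, known or untested is meant among the compounds shown, and "the series" means these compounds.

Compound 1 `O=C(NC1CCN(Cc2ccc3ccccc3c2)CC1)c1ccccc1`, 347 nM
Compound 2 `COc1ccc(C(=O)NC2CCN(Cc3ccc4ccccc4c3)CC2)cc1OC`, 1000 nM

Of the compounds shown here, two have been measured in an assay on isolated protein for binding affinity to melanin-concentrating hormone receptor 1 (Homo sapiens); a higher number here means a weaker inhibitor, a lower number a stronger inhibitor. Compound 1 gives 347 nM, and compound 2 gives 1000 nM. Among the compounds with values here, the one measured step, a 2.9-fold higher number from compound 1 to compound 2 (0.46 log units; beyond the scatter), places compound 2 at the highest number of the two, with compound 1 its only neighbour. The new compound, compound 3 `O=C(NC1CCN(Cc2ccc3ccccc3c2)CC1)c1ccc(F)cc1`, differs from compound 2 in one place: 4-fluorophenyl in place of 3,4-dimethoxyphenyl on a carbonyl carbon. Within the data shown here, the only step that bears on this change is a 2.9-fold higher number from compound 1 to compound 2 (0.46 log units; beyond the scatter), which showed what replacing the plain phenyl with the 3,4-dimethoxyphenyl does. Compound 3 removes that group again and carries a 4-fluorophenyl instead, which in its count of heavy atoms and acceptors stands nearer to compound 1 than to compound 2. Compound 3 is therefore expected to move back toward the number of compound 1, with a step of about a 2.9-fold lower number from compound 2 to compound 3 (0.46 log units; beyond the scatter) in this assay. The estimate for compound 3 is 350 nM, within a range of 120 nM to 1000 nM.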

Compound 3, inhibition constant: 36 nM
Compound 3: middle estimate off by 9.7-fold (0.99 log units), on the high side; measured number below the stated range.
By their numbers in this assay, from the lowest: compound 3; then compound 1; then compound 2.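

In this assay, the earlier compounds had shown only a loss from changing the ring on this carbonyl carbon, but fluoro in place of hydrogen on an aromatic carbon gives a 9.6-fold lower number from compound 1 to compound 3 (0.98 log units; beyond the scatter) and so shows that this position can also yield a gain. Exchanging the 3,4-dimethoxyphenyl for 4-fluorophenyl gives a 28-fold lower number from compound 2 to compound 3 (1.44 log units; beyond the scatter) as a large step, which places compound 3 lowest of the three, with its steps to both other compounds beyond the scatter. Nothing available explains why this change has so large an effect. The compounds shown leave open whether the gain is particular to fluorine, which a 4-chlorophenyl or 4-methylphenyl ring would test, and whether it depends on where the fluorine sits, which a 3-fluorophenyl ring would test. They also leave open whether one methoxy group or both accounts for the higher number of compound 2, which a 4-methoxyphenyl ring would help separate.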